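This account rests on a few compounds, and the source may have more. Where it says the series, first, only, none or still open, it means among the compounds named here.

Of the compounds shown here, three of one shared core have been measured in a functional assay on Hs-578T cells (Homo sapiens) for inhibition, read by sulforhodamine B assay, with a stated time of 48 h, tested at 10 uM; a lower number here means less inhibition, a higher number more inhibition at the concentration tested (going by the name of the read-out). Compound 1 `COc1ccc(-c2cn3ccnc3c(-c3ccc4ncn(C5CCCCC5)c4c3)n2)cc1` carries a 4-methoxyphenyl group and reaches 80%. Compound 2 `c1ccc2c(-c3cn4ccnc4c(-c4ccc5ncn(C6CCCCC6)c5c4)n3)cccc2c1` carries a naphthalen-1-yl group instead and gives 3.62%. Compound 3 `Clc1ccc(-c2cn3ccnc3c(-c3ccc4ncn(C5CCCCC5)c4c3)n2)cc1` carries a 4-chlorophenyl group and gives 6.35%. Compound 3 thus stands far below compound 1, the difference being a number 73.7 percentage points lower from compound 1 to compound 3 (beyond the scatter), while compound 2 and compound 3 lie within the scatter of each other, as a number 2.7 percentage points higher from compound 2 to compound 3 (within the scatter) shows.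

Compound 4 `Brc1ccc(-c2cn3ccnc3c(-c3ccc4ncn(C5CCCCC5)c4c3)n2)cc1` is the next member. Compared with compound 3 the change is bromo in place of chloro on an aromatic carbon. The step from methoxy to chloro was large and downward, a number 73.7 percentage points lower from compound 1 to compound 3 (beyond the scatter), so the group at this position matters. The step from naphthalen-1-yl to 4-chlorophenyl, however, was a number 2.7 percentage points higher from compound 2 to compound 3 (within the scatter), within the scatter. Going by the values given here, no measured step swaps one halogen for another, so the closest guide is that compound 2 and compound 3 sit at the same low level. The expectation is a step of a number 1.7 percentage points higher from compound 3 to compound 4 (within the scatter), which is no change beyond the scatter. Compound 4 is estimated at 8%, within a range from 0% to 25%.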

Compound 4, a percentage reported as inhibition, at one concentration (the size of the read-out at that concentration, not a potency): 24.5%
Estimate against measurement, compound 4: 16.5 percentage points below; low and high end bracket the measured number.
By their numbers in this assay, from the lowest: compounds 2 and 3 (each within the scatter of the next); then compound 4; then compound 1.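

In this assay, the 4-position of this phenyl ring responds even to a swap of one halogen for another: replacing a single chlorine atom with a single bromine atom gives a number 18.2 percentage points higher from compound 3 to compound 4 (beyond the scatter) and lifts the value clear of the low level that the chloro compound shares with the naphthalen-1-yl compound. The 4-bromophenyl group also stands apart from the naphthalen-1-yl group, with a number 20.9 percentage points higher from compound 2 to compound 4 (beyond the scatter) as the step, so the three low-scoring groups no longer form a single level, yet bromo does not recover what methoxy gives, as a number 55.5 percentage points lower from compound 1 to compound 4 (beyond the scatter) shows. Nothing available explains why these two halogens differ in this assay or why methoxy reaches so much further.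

Fluoro and iodo on the same carbon would show whether the numbers follow the halogens in order or whether bromo is a single exception. Going by these compounds, whether the high value of compound 1 is particular to methoxy also remains open, and ethoxy, hydroxy or dimethylamino at this position could help to settle that.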